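A few compounds are considered here, and "the series" means these few. Any claim that something is new, unique, unknown or untested is made for them only; others in the source may bear on it.

compound 1 `Cc1nn(-c2ccccc2)c2nc(O)c(-c3nc(N)cc(N)n3)cc12`: "not determined" (no result reported)
compound 2 `Cc1nn(-c2ccccc2)c2nc(OCc3ccccc3F)c(-c3nc(N)c(N4CCCC4)c(N)n3)cc12`: 12700 nM
compound 3 `Cc1nn(-c2ccccc2)c2nc(OCc3ccccc3F)c(-c3nc(N)c(N(C)C)c(N)n3)cc12`: 1100 nM

All entries refer to a functional assay on aorta (Rattus norvegicus, strain Sprague-Dawley); a higher number here means that more compound is needed for the effect, a lower number that less compound is needed. Among the measured compounds shown here, compound 3, at 1100 nM, holds the lowest of the only two numbers, and compound 1 offers no number for comparison.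

The next compound is compound 4 `CCCCOC(=O)Nc1c(N)nc(-c2cc3c(C)nn(-c4ccccc4)c3nc2OCc2ccccc2F)nc1N`. It carries (butoxycarbonyl)amino in place of dimethylamino on an aromatic carbon of the six-membered aromatic ring with 2 nitrogen, ortho to two amino groups ((butoxycarbonyl)amino in place of dimethylamino on an aromatic carbon).

For the measured compounds named here, only one measured step bears on this change. It is a 12-fold lower number from compound 2 to compound 3 (1.06 log units; beyond the scatter), large and beyond the scatter, with dimethylamino in place of pyrrolidin-1-yl on that same carbon. This shows that the number in this assay can respond strongly to the group at this place. However, no measured compound carries (butoxycarbonyl)amino, so the direction rests on a single pair. Dimethylamino gave the lower number of that pair, so a move away from it is expected to raise the number, though by less than the measured step.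

The expected change is a 2.3-fold higher number from compound 3 to compound 4 (0.36 log units; beyond the scatter), and the uncertainty is wide. For compound 4 the estimated value is 2500 nM, with an expected range from 400 nM to 15000 nM.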

Compound 4, half-maximal effective concentration: > 100000 nM
Compound 4: no number, only a limit; the forecaster's own chance of this, stated with the estimate: 10%; middle value at least 40-fold (1.60 log units) away from the limit.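

In this assay, the earlier pair showed only that exchanging pyrrolidin-1-yl for dimethylamino on this aromatic carbon moves the number; (butoxycarbonyl)amino now gives an at least 90-fold higher number from compound 3 to compound 4 (1.95 log units; beyond the scatter). The same group also ends up on the high side of compound 2, the higher of the two earlier numbers, with an at least 7.8-fold higher number from compound 2 to compound 4 (0.89 log units; beyond the scatter), so the response at this place is not confined to the gap between those two amino substituents. Both steps are bounds rather than exact sizes, as compound 4 has no number and sits at a limit of the assay: the limit of > 100000 nM in this assay, at which 1 of the 4 values shown sits.

The entering group differs from dimethylamino in several ways at once, including its longer chain, its carbonyl and its hydrogen-bond donor, and the three compounds with a reading at this place cannot separate these features. A methoxycarbonylamino group would test the butyl chain, while a plain amino group or an acetylamino group on the same carbon would test the carbamate link, leaving open which part accounts for the high limit of compound 4.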